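The source may report more compounds than this note shows. Statements on the series, on what has been measured and on what is new or still open speak of the compounds shown alone.

Among the compounds with values here, compound 3 `NCCCCCCNc1c(C(=O)NCc2ccc(F)cc2)nc(Br)c2cccnc12` is the one member of this group with a numbered result in a functional assay on HT-29 cells (Homo sapiens) for cytotoxicity, read by MTT assay, with a stated time of 72 h (a higher number here means a weaker inhibitor, a lower number a stronger inhibitor), where compound 3 gives 5000 nM. Compound 1 `N[C@H]1CC[C@H](Nc2c(C(=O)NCc3ccc(F)cc3)nc(Br)c3cccnc23)CC1` reaches only a limit of the assay, < 1000 nM. Compound 2 `O=C(NCCCNc1c(C(=O)NCc2ccc(F)cc2)nc(Br)c2cccnc12)c1ccccc1` likewise stops at a limit, > 10000 nM. Compound 4 `CN(C)CCCNc1c(C(=O)NCc2ccc(F)cc2)nc(Br)c2cccnc12` carries dimethylamino in place of 3-aminopropyl on a saturated chain carbon, three bonds along the chain from a nitrogen on an aromatic ring. Within the data shown here, two measured steps touch this place: an at least 5.0-fold higher number from compound 1 to compound 3 (0.69 log units; beyond the scatter) and an at least 2.0-fold lower number from compound 2 to compound 3 (0.30 log units; that floor lies within the scatter). The second, exchanging the same 3-aminopropyl, bears most directly and is small against the scatter; the first is at least modest. For compound 4 a small shift toward the weaker side is therefore expected, a 1.4-fold higher number from compound 3 to compound 4 (0.15 log units; within the scatter). The estimate for compound 4 is 7000 nM, spanning 2500 nM to 20000 nM.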

Compound 4, half-maximal inhibitory concentration: 6000 nM
Compound 4: the middle estimate sits 1.2-fold (0.07 log units) above what was measured; low and high end bracket the measured number.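

In this assay, replacing 6-aminohexyl with 3-(dimethylamino)propyl takes the hydrogen-bond donors of the group from 1 to 0 and gives a 1.2-fold higher number from compound 3 to compound 4 (0.08 log units; within the scatter), so compound 3 and compound 4 cannot be told apart at this position. The comparison with the benzamido group gives only a floor, an at least 1.6-fold lower number from compound 2 to compound 4 (0.22 log units; that floor lies within the scatter), which does not separate those two compounds either. The step of an at least 6.0-fold higher number from compound 1 to compound 4 (0.77 log units; beyond the scatter) shows that 4-aminocyclohexyl stays apart from this second open chain, as it did from 6-aminohexyl. Going by these compounds, whether a morpholine or pyrrolidine in place of dimethylamino would shift the number remains open. So does the effect of dimethylamino on the cyclohexyl ring in place of its amine.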